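The source may report more compounds than this note shows. Statements on the series, on what has been measured and on what is new or still open speak of the compounds shown alone.

Measured so far:
compound 1 `Nc1nc(=O)[nH]c2c1c(-c1ccccc1)cn2-c1ccc(S(=O)(=O)Nc2nccs2)cc1` gives 8320 nM in a functional assay on MCF7 cells (Homo sapiens) for inhibition, read by sulforhodamine B assay, with a stated time of 24 h; a lower number here means a stronger inhibitor, a higher number a weaker inhibitor;
compound 2 `Nc1nc(=O)[nH]c2c1c(-c1ccccc1)cn2-c1ccc(S(=O)(=O)Nc2ccccn2)cc1` gives 3900 nM in this assay;
compound 3 `Nc1nc(=S)[nH]c2c1c(-c1ccccc1)cn2-c1ccc(S(=O)(=O)Nc2nccs2)cc1` gives 3120 nM in this assay.

Compounds 1 and 2 share one core and differ only at the sulfonamide nitrogen: pyridin-2-yl in place of 1,3-thiazol-2-yl on a sulfonamide nitrogen. That exchange gave a 2.1-fold lower number from compound 1 to compound 2 (0.33 log units; beyond the scatter), a change that is modest but reaches beyond the usual scatter of repeated measurements.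

Compound 3 is built on a different core. Within the data shown here, the difference between the core of compound 3 and the core of compound 1 is not broken down here; the two values show only that compound 3 gives a lower number than compound 1 does, while compound 3 and compound 2 give numbers that lie within the scatter of each other, so no order between those two can be read.

Compound 4 `Nc1nc(=S)[nH]c2c1c(-c1ccccc1)cn2-c1ccc(S(=O)(=O)Nc2ccccn2)cc1` is not yet measured. It relates to compound 3 exactly as compound 2 relates to compound 1: pyridin-2-yl in place of 1,3-thiazol-2-yl on a sulfonamide nitrogen. The place of the exchange is described in the same words in both pairs, so this is the same change made on the other core.

Among the measured compounds shown here, with only one earlier instance of this change to rest on, compound 4 is expected to show about the same step in this assay, that is a 2.0-fold lower number from compound 3 to compound 4 (0.29 log units; within the scatter), because the earlier exchange gave a 2.1-fold lower number from compound 1 to compound 2 (0.33 log units; beyond the scatter). On that basis compound 4 is estimated at 1600 nM, with a likely range from 700 nM to 3600 nM.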

Compound 4, half-maximal inhibitory concentration: 3800 nM
The estimate for compound 4 lay 2.4-fold (0.38 log units) below the measured number; measured number above the stated range.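

In this assay, among these compounds, putting pyridin-2-yl in place of 1,3-thiazol-2-yl on a sulfonamide nitrogen of the second core gives a 1.2-fold higher number from compound 3 to compound 4 (0.09 log units; within the scatter), so on this core the exchange produces no step that can be told apart from the ordinary spread of repeated measurements. Set beside the earlier case, the two results cannot be called different, even though one step lies beyond the scatter and the other within it: the same change on two cores in this assay, a 2.1-fold lower number (0.33 log units; beyond the scatter) from compound 1 to compound 2 and a 1.2-fold higher number (0.09 log units; within the scatter) from compound 3 to compound 4, 2.6-fold (0.41 log units) apart, within the scatter of two such steps. This shows that the data are compatible with the change carrying over from one core to the other, but it does not prove that it does, and it does not show that the core alters the effect of the change, as two small steps from two pairs of compounds cannot settle either point.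

The compounds shown leave open whether another group on the sulfonamide nitrogen, such as a pyrimidin-2-yl ring, an acetyl group or a plain methyl, would give a step large enough to stand clear of the scatter on both cores. Also open, going by these compounds, is whether the exchange would behave the same way on a third core, for instance one carrying a methoxy group on its phenyl ring.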